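The source may hold more compounds than are shown below. What is called first, only, known or untested is meant among the compounds shown, and "the series" means these compounds.

Compound 1 `Cc1cc(C)c(Oc2cc(Nc3ccc(C#N)cc3)ncc2C(=O)NCc2cn(Cc3ccccc3C#N)nn2)c(C)c1`: in an ADME assay on MT4 cells (Homo sapiens) for cytotoxicity, read by MTT assay, with a stated time of 5 days (on this read-out higher numbers stand for lower toxicity in this test and lower numbers for higher toxicity in this test), compound 1 reaches only the limit > 219000 nM.
Compound 2 `Cc1cc(C)c(Oc2cc(Nc3ccc(C#N)cc3)ncc2C(=O)NCc2cn(CC(N)=O)nn2)c(C)c1`: in this assay compound 2 gives 24000 nM.
Compound 3 `Cc1cc(C)c(Oc2cc(Nc3ccc(C#N)cc3)ncc2C(=O)NCc2cn(Cc3cccc(C#N)c3)nn2)c(C)c1`: in this assay compound 3 reaches only the limit >= 129000 nM.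

Compound 3 thus stands at a limit rather than at a number; two of the three values are limits, namely the limit of > 219000 nM in this assay, at which 1 of the 3 values shown sits, and (the limit of >= 129000 nM in this assay, at which 1 of the 3 values shown sits), and only compound 2 gives a number. The unmeasured compound 4 `Cc1cc(C)c(Oc2cc(Nc3ccc(C#N)cc3)ncc2C(=O)NCc2cn(CCCO)nn2)c(C)c1` differs from compound 3 by 2-hydroxyethyl in place of 3-cyanophenyl on a saturated chain carbon bound to an aromatic nitrogen. The measured steps that bear on this change are those that exchange a cyanophenyl group for a small non-aromatic group on that chain carbon: an at least 9.1-fold lower number from compound 1 to compound 2 (0.96 log units; beyond the scatter) and an at least 5.3-fold higher number from compound 2 to compound 3 (0.73 log units; beyond the scatter); a step that the two limits leave unreadable from compound 1 to compound 3. Both readable steps point the same way, the carbamoyl compound sitting well below either cyanophenyl limit. Since the 2-hydroxyethyl group is likewise small and non-aromatic, an at least modest step toward lower numbers is expected in this assay from compound 3 to compound 4, an at least 2.5-fold lower number from compound 3 to compound 4 (0.41 log units; beyond the scatter). Compound 4 is therefore estimated at 50000 nM, with a range from 15000 nM to 200000 nM.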

Compound 4, half-maximal cytotoxic concentration: 25200 nM
Estimate against measurement, compound 4: 2.0-fold (0.30 log units) above; measured number inside the range.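

Compound 4 shows that the lower reading in this assay is not particular to carbamoyl: 2-hydroxyethyl, which also has no ring, gives a 1.1-fold higher number from compound 2 to compound 4 (0.02 log units; within the scatter), while replacing the cyanophenyl groups gives an at least 5.1-fold lower number from compound 3 to compound 4 (0.70 log units; beyond the scatter) and an at least 8.6-fold lower number from compound 1 to compound 4 (0.93 log units; beyond the scatter). Compound 3 stands at a limit and not at a number: the limit of >= 129000 nM in this assay, at which 1 of the 4 values shown sits. Compound 1 also stands at a limit and not at a number: the limit of > 219000 nM in this assay, at which 1 of the 4 values shown sits.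

The aromatic ring, the nitrile and the larger group size all leave together in these changes, so the compounds shown do not tell which of them goes with the higher readings. A phenyl group without the nitrile, a long alkyl chain without oxygen or an amine on the chain would separate these features.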